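The source may hold more compounds than are shown below. What is called first, only, known or untested is meant among the compounds shown, and "the series" means these compounds.

Compound 1 `CC(C)(C)n1ncc(OCc2nnc(-c3cccs3)o2)c(Cl)c1=O`: in a functional assay on the whole organism for inhibition, with Mythimna separata as the target, with a stated time of 5 days (a higher number here means that more compound is needed for the effect, a lower number that less compound is needed), compound 1 reaches only the limit of > 299000 nM.
Compound 2 `CCc1ccc(-c2nnc(COc3cnn(C(C)(C)C)c(=O)c3Cl)o2)cc1`: in this assay compound 2 gives 14500 nM.

Among the measured compounds shown here, compound 2 therefore holds the only measured number in this assay; the other compound sits at the limit of > 299000 nM in this assay, at which 1 of the 2 values shown sits. For the measured compounds named here, the one measured step, an at least 20-fold lower number from compound 1 to compound 2 (1.31 log units; beyond the scatter), shows that exchanging the aryl group attached to the shared core can move the number a long way, although the start of that step is a limit, so its true size is not known.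

Compound 3 `COc1ccc(-c2nnc(COc3cnn(C(C)(C)C)c(=O)c3Cl)o2)cc1` keeps the whole frame of compound 2 and differs only in methoxy in place of ethyl on an aromatic carbon. Going by the values given here, no measured step touches this position; the single step known concerns the ring itself, not a substituent on it. The expectation therefore leans on the similar size of the two groups, and a step of a 1.4-fold higher number from compound 2 to compound 3 (0.14 log units; within the scatter), within the usual scatter, is expected. Compound 3 is estimated at 20000 nM in this assay, with a range from 6000 nM to 70000 nM.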

Compound 3, half-maximal effective concentration: 17700 nM
Compound 3: middle estimate off by 1.1-fold (0.05 log units), on the high side; low and high end bracket the measured number.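

Para to a large group on the six-membered aromatic ring, ethyl and methoxy cannot be told apart in this assay (a 1.2-fold higher number from compound 2 to compound 3 (0.09 log units; within the scatter)), so here the exchange of two carbons for a carbon and an oxygen, which adds one hydrogen-bond acceptor, leaves the number within the scatter. The earlier compounds showed one large step away from the thiophen-2-yl compound, and the 4-methoxyphenyl group now gives a second one (an at least 16-fold lower number from compound 1 to compound 3 (1.22 log units; beyond the scatter)), so among these compounds the large step is not tied to the ethyl group. The true size of this second step remains unknown, because the value for compound 1 is a limit and not a number: the limit of > 299000 nM in this assay, at which 1 of the 3 values shown sits.

As far as these compounds go, the two groups compared here have the same count of heavy atoms, so it remains open whether an amine, a carboxylic acid or a longer chain such as hexyl at this place would leave the number just as unchanged. A plain phenyl group would also be needed to tell whether the large steps come with the six-membered ring itself or depend on having a group at this place.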